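Alkylamino variation on the thiadiazole end of the series

A few compounds are considered here, and "the series" means these few. Any claim that something is new, unique, unknown or untested is made for them only; others in the source may bear on it.

Compound 1 `C=CCNc1nnc(SCC(=O)N(Cc2cccc([N+](=O)[O-])c2)c2ccc(F)cc2)s1` and compound 2 `CCNc1nnc(SCC(=O)N(Cc2cccc([N+](=O)[O-])c2)c2ccc(F)cc2)s1` share one core and differ only at the chain on the ring nitrogen. In an assay on isolated protein for inhibition of Amine oxidase [flavin-containing] A (Homo sapiens), read by fluorescence and Amplex Red, with a stated time of 30 min, tested at 100 uM (a lower number here means a weaker effect, a higher number a stronger effect of the compound at the concentration tested), compound 1 gives 86.4%, and compound 2 gives 89.5%; the step of a number 3.1 percentage points higher from compound 1 to compound 2 (within the scatter) is within the scatter. Compound 2 thus stands at the top of the two numbers shown, with compound 1 inside the scatter of it.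

Compound 3 `CC(C)CNc1nnc(SCC(=O)N(Cc2cccc([N+](=O)[O-])c2)c2ccc(F)cc2)s1` carries isopropyl in place of methyl on a saturated chain carbon bound to a nitrogen on an aromatic ring. Among the measured compounds shown here, the only step bearing on this place, a number 3.1 percentage points higher from compound 1 to compound 2 (within the scatter), was small, so no change beyond the scatter is expected: a number 2.5 percentage points lower from compound 2 to compound 3 (within the scatter). Compound 3 is therefore estimated at 87%, within 74% to 95%.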

Compound 3, a percentage reported as inhibition, at one concentration (the size of the read-out at that concentration, not a potency): 84.3%
For compound 3 the middle estimate is 2.7 percentage points above the measured one; low and high end bracket the measured number.
By their numbers in this assay, from the lowest: compounds 3, 1 and 2 (each within the scatter of the next).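

Going from ethylamino to isobutylamino puts a branched chain at this position, yet the read-out in this assay does not separate the two (a number 5.2 percentage points lower from compound 2 to compound 3 (within the scatter)). Isopropyl in place of vinyl reads the same way (a number 2.1 percentage points lower from compound 1 to compound 3 (within the scatter)), so the three chains on the shared core cannot be told apart at the single concentration tested. No supporting data bear on this flat result.

On these data alone, whether the position stays this flat with a terminal amine, a carboxylic acid, a longer chain or a cyclohexyl ring remains open. Any potency differences among these three compounds also remain open.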